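The source may report more compounds than this note shows. Statements on the series, on what has been measured and on what is new or still open speak of the compounds shown alone.

Measured so far in a functional assay on HOS cells (Homo sapiens) for inhibition, with a stated time of 72 h; on this read-out lower numbers stand for stronger inhibition and higher numbers for weaker inhibition:
- Compound 1 `NC1CCC(Nc2nc(NCc3ccc(Br)cc3)c3ncn(C4CCCC4)c3n2)CC1`: 995 nM
- Compound 2 `NC1CCC(Nc2nc(NCc3ccc(-c4ccccc4)cc3)c3ncn(C4CCCC4)c3n2)CC1`: 290 nM
- Compound 3 `CC(C)(O)CNc1nc(NCc2ccc(-c3ccco3)cc2)c2ncn(C3CCCC3)c2n1`: 21400 nM

Compound 2 has the lowest number of the three, at 290 nM. Compound 4 `NC1CCC(Nc2nc(NCc3ccc(-c4ccccc4)nc3)c3ncn(C4CCCC4)c3n2)CC1` differs from compound 2 in one place: 6-phenylpyridin-3-yl in place of 4-phenylphenyl on a saturated chain carbon bound to a nitrogen on an aromatic ring. In words, this is 6-phenylpyridin-3-yl in place of 4-phenylphenyl on a saturated chain carbon bound to a nitrogen on an aromatic ring.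

Going by the values given here, only one measured step bears on this change, and only indirectly. It is a 3.4-fold lower number from compound 1 to compound 2 (0.54 log units; beyond the scatter), with phenyl in place of bromo on an aromatic carbon. Among the compounds with values here, this modest step shows that the number in this assay can move when that group changes, but no measured pair swaps a ring of carbon only for a ring with a hetero atom. Compound 3 differs from compound 2 in more than one place, so the value of compound 3, 21400 nM, gives little guidance here.

The step is therefore expected to be no larger than the modest one from compound 1, with a slightly higher number somewhat more likely than a lower one, and the direction remains uncertain. The estimated step is a 1.4-fold higher number from compound 2 to compound 4 (0.14 log units; within the scatter). For compound 4 the expected value is 400 nM, with an estimated range of 130 nM to 1200 nM.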

Compound 4, half-maximal inhibitory concentration: 206 nM
Compound 4: middle estimate off by 1.9-fold (0.29 log units), on the high side, and the stated range covers the measured number.
By their numbers in this assay, from the lowest: compounds 4 and 2 (each within the scatter of the next); then compound 1; then compound 3.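

In this assay compound 4 carries 6-phenylpyridin-3-yl where compound 2 carries 4-phenylphenyl, and the step (a 1.4-fold lower number from compound 2 to compound 4 (0.15 log units; within the scatter)) lies within the scatter, so this read-out does not tell the two compounds apart. The earlier compounds shown here showed only that phenyl in place of bromo on an aromatic carbon could lower the number, whereas compound 4 shows that a six-membered aromatic ring with 1 hetero atom can replace one of carbon only in this group while the number stays beyond the scatter of the 4-bromophenyl compound (a 4.8-fold lower number from compound 1 to compound 4 (0.68 log units; beyond the scatter)). No measurement at hand accounts for this result.

On these data alone, whether a pyrimidine ring in place of the pyridine, or an amine or a carboxylic acid on the outer phenyl ring, would keep the number in this range remains open. Compound 3 differs from these compounds in more than one place, so how much its changes each contribute to its 21400 nM also remains unresolved.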